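Hydrazone aryl variation in the cytotoxicity series

The compounds below may be only part of what the source reports. "The series", "measured", "known", "first", "only" and "open" are said of these compounds alone.

Compound 2 `COc1ccccc1-c1nnc(-c2ccc(C(=O)N/N=C/c3ccccn3)cc2)o1` gives the lowest number of the three measured in an ADME assay on THP-1 cells (Homo sapiens) for cytotoxicity (on this read-out lower numbers stand for stronger inhibition and higher numbers for weaker inhibition), at 67000 nM. Compound 1 `COc1ccccc1-c1nnc(-c2ccc(C(=O)N/N=C/c3ccncc3)cc2)o1` gives 173000 nM, and compound 3 `COc1ccc(/C=N/NC(=O)c2ccc(-c3nnc(-c4ccccc4OC)o3)cc2)c(O)c1` gives 308000 nM; the steps of a 2.6-fold lower number from compound 1 to compound 2 (0.41 log units; beyond the scatter) and a 4.6-fold higher number from compound 2 to compound 3 (0.66 log units; beyond the scatter) both lie beyond the scatter, while a 1.8-fold higher number from compound 1 to compound 3 (0.25 log units; within the scatter) does not. The change to compound 4 `COc1ccccc1-c1nnc(-c2ccc(C(=O)N/N=C/c3ccccc3O)cc2)o1` is 2-hydroxyphenyl in place of pyridin-2-yl on a carbon with a double bond to nitrogen. The step that bears on it most is a 4.6-fold higher number from compound 2 to compound 3 (0.66 log units; beyond the scatter), which also replaced pyridin-2-yl by a hydroxy-bearing phenyl, though with an extra methoxy; the pair with compound 1 concerns a different swap. Among the compounds with values here, a modest rise beyond the scatter is therefore expected, smaller than the one to compound 3, giving a 2.7-fold higher number from compound 2 to compound 4 (0.43 log units; beyond the scatter). Compound 4 is estimated at 180000 nM, in the range 80000 nM to 400000 nM.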

Compound 4, half-maximal inhibitory concentration: 207000 nM
For compound 4 the middle estimate is 1.2-fold (0.06 log units) below the measured one; the measured number falls inside the stated range.
By their numbers in this assay, from the lowest: compound 2; then compounds 1, 4 and 3 (each within the scatter of the next).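

In this assay the swap on the carbon with a double bond to nitrogen gives a 3.1-fold higher number from compound 2 to compound 4 (0.49 log units; beyond the scatter) and so shows, without the extra methoxy of compound 3, that 2-hydroxyphenyl alone does not keep the low number of compound 2. Hydrogen in place of methoxy gives a 1.5-fold lower number from compound 3 to compound 4 (0.17 log units; within the scatter) and 2-hydroxyphenyl in place of pyridin-4-yl gives a 1.2-fold higher number from compound 1 to compound 4 (0.08 log units; within the scatter) and so, among these four compounds, only pyridin-2-yl stands apart at this position. No supporting data explain the pyridin-2-yl result.

Open, from the compounds shown here alone, is whether pyridin-3-yl or a 2-aminophenyl group on the same carbon would follow compound 2 or compound 4.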